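Adding a Cinnamoyl Cap to the Amine of Compound 2

This account rests on a few compounds, and the source may have more. Where it says the series, first, only, none or still open, it means among the compounds named here.

Compound 1 `CCCCCCCCCCCCCCNC(=O)[C@@H](N)[C@@H](C)O` gives 18700 nM.
Compound 2 `CCCCCCCCCCCCCCCCCCNC(=O)[C@@H](N)[C@@H](C)O` gives 21400 nM.
Compound 3 `C/C=C/C=C/C(=O)N[C@H](C(=O)NCCCCCCCC)[C@@H](C)O` gives 200000 nM.

These three compounds were tested in a functional assay on SW-620 cells (Homo sapiens) for cytotoxicity, read by MTT assay, with a stated time of 48 h; on this read-out higher numbers stand for weaker inhibition and lower numbers for stronger inhibition. Compound 2 stands second highest of the three numbers; its nearest neighbour is compound 1, separated by a 1.1-fold higher number from compound 1 to compound 2 (0.06 log units; within the scatter), so the longer chain in compound 2 made no difference that can be trusted. Compound 3, with its acylated amine and shorter chain, gives a number far higher than compound 2, but it differs from compound 2 in two places, so only the two values themselves can be compared.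

Compound 4 `CCCCCCCCCCCCCCCCCCNC(=O)[C@@H](NC(=O)/C=C/c1ccccc1)[C@@H](C)O` has not yet been measured. It is compound 2 with one change: (2-phenylethenyl)carbonyl in place of hydrogen on an amine nitrogen. Going by the values given here, no measured step captures exactly this change. Among the compounds with values here, the only guidance is that compound 3, which also carries an acyl group on the amine, gives the weakest number of the three, while the chain-length step between compound 1 and compound 2 lay within the scatter. On that basis compound 4 is expected to be weaker than compound 2, with an expected step of a 4.7-fold higher number from compound 2 to compound 4 (0.67 log units; beyond the scatter) in this assay. Compound 4 is therefore estimated at 100000 nM, with a range from 30000 nM to 300000 nM.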

Compound 4, half-maximal inhibitory concentration: 200000 nM
Beside the measured number, compound 4's estimate is 2.0-fold (0.30 log units) below it; the measured number falls inside the stated range.
By their numbers in this assay, from the lowest: compounds 1 and 2 (each within the scatter of the next); then compounds 3 and 4 (each within the scatter of the next).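

In this assay, placing (2-phenylethenyl)carbonyl on the amine nitrogen of compound 2 gives a 9.3-fold higher number from compound 2 to compound 4 (0.97 log units; beyond the scatter), the only step shown at this position. Going by these compounds alone, the one earlier single-place change lay far out along the chain and stayed within the scatter, whereas this one shows that a change on the amine nitrogen can clearly move the number, here towards weaker inhibition with the long chain left as it is. Nothing measured here accounts for this loss, so its reason stays unknown.

Going by these compounds, it remains open whether the loss belongs to the phenyl ring, to the double bond or to any acyl group on this nitrogen; an acetyl group or a saturated 3-phenylpropanoyl group on the same amine would help to separate these possibilities. On these data alone, it is also open whether a benzyl group, which would leave the nitrogen an amine, would hold the level of compound 2 at 21400 nM or weaken it in the same way.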